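The source may report more compounds than this note shows. Statements on the series, on what has been measured and on what is new or still open speak of the compounds shown alone.

Measured compounds:
- compound 1 `COc1ccc(Cn2nc(-c3ccccc3)c3cc(C(=N)Nc4ccccc4)ncc32)cc1` — 6300 nM
- compound 2 `COc1ccc(Cn2nc(-c3ccccc3)c3cc(C(=N)Nc4cccc(C(F)(F)F)c4)ncc32)cc1` — a limit only, > 50000 nM
- compound 3 `COc1ccc(Cn2ncc3cc(C(=N)Nc4ccccc4)ncc32)cc1` — 36000 nM

In a functional assay on PC-3 cells (Homo sapiens) for cytotoxicity, read by MTT assay, with a stated time of 72 h (on this read-out higher numbers stand for weaker inhibition and lower numbers for stronger inhibition), compound 1 gives 6300 nM and stands lowest of the two numbers shown. The nearest number is that of compound 3, with a 5.7-fold higher number from compound 1 to compound 3 (0.76 log units; beyond the scatter) on removal of the phenyl. Compound 2 reports only a limit, (the limit of > 50000 nM in this assay, at which 1 of the 3 values shown sits).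

Compound 4 `COc1ccc(Cn2nc(-c3ccccc3)c3cc(C(=N)Nc4ccc(N5CCN(C)CC5)cc4)ncc32)cc1` differs from compound 1 by 4-methylpiperazin-1-yl in place of hydrogen on an aromatic carbon. Going by the values given here, of the two measured steps, the one from compound 1 to compound 2 is the closer parallel, since it also places a new group on an aromatic carbon of that ring; it gave an at least 7.9-fold higher number from compound 1 to compound 2 (0.89 log units; beyond the scatter). The step to compound 3 concerns the phenyl on the shared core and does not bear on the change here. Among the compounds with values here, the only precedent for substitution on this ring is thus a rise in the number to a limit, though with a different group. The step is expected to go in the same direction, upward, but its size is uncertain, and the estimate is kept broad. Compound 4 is expected to give about 14000 nM, within 4000 nM to 50000 nM. This corresponds to an expected step of a 2.2-fold higher number from compound 1 to compound 4 (0.35 log units; beyond the scatter).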

Compound 4, half-maximal inhibitory concentration: 3990 nM
For compound 4 the middle estimate is 3.5-fold (0.55 log units) above the measured one, and the stated range ends above it.
By their numbers in this assay, from the lowest: compounds 4 and 1 (each within the scatter of the next); then compound 3. At a limit, above all of these: compound 2.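

In this assay, the step for 4-methylpiperazin-1-yl in place of hydrogen on an aromatic carbon, para to a large group, is a 1.6-fold lower number from compound 1 to compound 4 (0.20 log units; within the scatter), which shows that this position can carry a substituent of this size with no shift beyond the scatter. The only earlier substitution on this ring, trifluoromethyl in compound 2, ends in a limit, so a rise in the number is not general to every group placed on this ring: the limit of > 50000 nM in this assay, at which 1 of the 4 values shown sits. Nothing measured here accounts for the different outcomes of these two groups.

The compounds shown hold no pair with a single group moved around this ring, so the effect of the group and the effect of its place cannot be told apart. Also open, from the compounds shown here alone, is how a morpholine or a carboxylic acid in the same place would read, and whether the result for 4-methylpiperazin-1-yl holds without the phenyl on the shared core.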